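Swapping Chloro for Methoxy on the Benzoyl Ring

The compounds below may be only part of what the source reports. "The series", "measured", "known", "first", "only" and "open" are said of these compounds alone.

- compound 1 `Cc1ccc(C(=O)N2CCN(CC(=O)N3CCN(CCCc4c[nH]c5ccc(F)cc45)CC3)CC2)cc1`: 141000 nM
- compound 2 `O=C(CN1CCN(C(=O)c2cccc(Cl)c2)CC1)N1CCN(CCCc2c[nH]c3ccc(F)cc23)CC1`: 66200 nM

Among the compounds with values here, in an ADME assay on HEK293 cells (Homo sapiens) for cytotoxicity, read by MTT assay, with a stated time of 72 h (a higher number here means a weaker inhibitor, a lower number a stronger inhibitor), compound 2 gives the lower of the two numbers so far, at 66200 nM. The next compound is compound 3 `COc1cccc(C(=O)N2CCN(CC(=O)N3CCN(CCCc4c[nH]c5ccc(F)cc45)CC3)CC2)c1`, which has methoxy in place of chloro on an aromatic carbon, meta to a large group: methoxy in place of chloro on an aromatic carbon.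

Within the data shown here, only one measured step bears on this change: a 2.1-fold lower number from compound 1 to compound 2 (0.33 log units; beyond the scatter). It is modest, and it replaces 4-methylphenyl with 3-chlorophenyl on a carbonyl carbon, so it offers only indirect guidance. Among the measured compounds shown here, no measured compound carries methoxy. With so little evidence, compound 3 is expected to fall near the span set by the two measured compounds, with compound 1 at its upper end at 141000 nM. A small move toward a higher number is therefore expected, possibly none beyond the scatter. The estimated change is a 1.4-fold higher number from compound 2 to compound 3 (0.16 log units; within the scatter). Compound 3 is estimated at 95000 nM. Its expected range runs from 50000 nM to 180000 nM.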

Compound 3, half-maximal inhibitory concentration: 87100 nM
Beside the measured number, compound 3's estimate is 1.1-fold (0.04 log units) above it, within the range that was stated.
By their numbers in this assay, from the lowest: compounds 2, 3 and 1 (each within the scatter of the next, the first and the last beyond it).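

In this assay, replacing chloro with methoxy on an aromatic carbon, meta to a large group, gives a 1.3-fold higher number from compound 2 to compound 3 (0.12 log units; within the scatter) and so does not separate the two groups at this position, even though methoxy brings one more heavy atom and a hydrogen-bond acceptor that chloro lacks. The second new comparison, from 4-methylphenyl to 3-methoxyphenyl, gives a 1.6-fold lower number from compound 1 to compound 3 (0.21 log units; within the scatter) and also stays short of a clear difference, whereas the earlier step, a 2.1-fold lower number from compound 1 to compound 2 (0.33 log units; beyond the scatter), lay beyond the scatter. Compound 3 therefore cannot be told apart from either of the other two compounds, which leaves the earlier gap bridged by a compound close to both ends, and nothing available here accounts for these small steps.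

The compounds shown leave open whether an amine or a carboxylic acid in place of chloro at this position would give a number clearly apart from these. They also leave open whether 4-methoxyphenyl would read like 3-methoxyphenyl, and whether a change away from this aromatic ring, in the shared core, would matter more than any of these swaps.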